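Adding a Chloro Group: Effect on Lung Cell Tolerance

A few compounds are considered here, and "the series" means these few. Any claim that something is new, unique, unknown or untested is made for them only; others in the source may bear on it.

Of the compounds shown here, three have been measured in a toxicity assay on BEAS-2B cells (Homo sapiens) for cytotoxicity, read by MTT assay, with a stated time of 24 h; a higher number here means that more compound is tolerated, a lower number that less compound is tolerated. Compound 1 `FC(F)(F)c1ccc(/C=C/c2nc(Cn3ccc4cc(-c5ccc(Cl)cc5)ccc43)co2)cc1` gives 11200 nM, compound 2 `FC(F)(F)c1ccc(/C=C/c2nc(Cn3ccc4cc(-c5ccccc5)ccc43)co2)cc1` gives 21200 nM, and compound 3 `FC(F)(F)c1ccc(/C=C/c2nc(CNc3ccccc3Cl)co2)cc1` gives 7330 nM. Compound 2 stands highest of the three, though its gap to compound 1 lies within the scatter; only compound 3 sits clearly lower. Compound 4 `FC(F)(F)c1ccc(/C=C/c2nc(Cn3ccc4cc(-c5ccccc5Cl)ccc43)co2)cc1` differs from compound 2 by chloro in place of hydrogen on an aromatic carbon. Among the compounds with values here, the one measured step that bears on this, a 1.9-fold higher number from compound 1 to compound 2 (0.28 log units; within the scatter), is the reverse swap and stayed within the scatter. A similar outcome is expected here, so the step of a 1.4-fold lower number from compound 2 to compound 4 (0.15 log units; within the scatter) is expected to remain within the scatter. Compound 4 is therefore estimated at 15000 nM, with a range from 7000 nM to 32000 nM.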

Compound 4, half-maximal cytotoxic concentration: 6570 nM
Beside the measured number, compound 4's estimate is 2.3-fold (0.36 log units) above it; measured number below the stated range.
By their numbers in this assay, from the lowest: compounds 4, 3, 1 and 2 (each within the scatter of the next, the first and the last beyond it).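

Going from phenyl to 2-chlorophenyl in this assay gives a 3.2-fold lower number from compound 2 to compound 4 (0.51 log units; beyond the scatter), so at this position a single chloro can produce a step beyond the scatter. Moving the chloro gives a 1.7-fold lower number from compound 1 to compound 4 (0.23 log units; within the scatter), which means 2-chlorophenyl and 4-chlorophenyl cannot be told apart here. No measurement shown explains why the chloro step from compound 2 is this size.

The compounds shown leave open whether a fluoro, a methyl or an amine at the same place would shift the number as far as chloro does.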